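Ester to acid on the biphenyl of compound 1

The compounds below may be only part of what the source reports. "The series", "measured", "known", "first", "only" and "open" are said of these compounds alone.

Compound 1, with structure `COC(=O)c1ccccc1-c1ccc(CCc2ncc(CC(C)(C)C)n2CC(=O)O)cc1`, sits at the top of the three numbers in an assay on cells for agonist activity at Bombesin receptor subtype-3 (Mus musculus), read by HTRF and inositol phosphate accumulation, with a stated time of 1 h; a lower number here means that less compound is needed, a higher number that more compound is needed for the effect: compound 1 gives 694 nM. Compound 2, `COC(=O)c1c(F)cccc1-c1ccc(CCc2ncc(CC(C)(C)C)n2Cc2ccc(C(=O)O)cc2)cc1`, gives 5 nM, and compound 3, `COC(=O)c1c(F)cccc1-c1ccc(CCc2ncc(CC(C)(C)C)n2CCOc2cccc(O)c2)cc1`, gives 25 nM. Among the measured compounds shown here, the only measured step, a 5.0-fold higher number from compound 2 to compound 3 (0.70 log units; beyond the scatter), changes a group on a saturated chain carbon bound to an aromatic nitrogen, not the position altered here. Compound 4, `CC(C)(C)Cc1cnc(CCc2ccc(-c3ccccc3C(=O)O)cc2)n1CC(=O)O`, differs from compound 1 by hydrogen in place of methyl on an oxygen next to a carbonyl group, so methoxycarbonyl becomes carboxy. For the measured compounds named here, no measured step speaks to this change, so the expectation leans on compound 1 alone. A modest rise in the number is expected, a 2.2-fold higher number from compound 1 to compound 4 (0.33 log units; beyond the scatter), giving an estimate for compound 4 of 1500 nM within 400 nM to 6000 nM.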

Compound 4, half-maximal effective concentration: 1270 nM
The estimate for compound 4 lay 1.2-fold (0.07 log units) above the measured number; low and high end bracket the measured number.
By their numbers in this assay, from the lowest: compound 2; then compound 3; then compounds 1 and 4 (each within the scatter of the next).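

In this assay, the swap of 2-(methoxycarbonyl)phenyl for 2-carboxyphenyl gives a 1.8-fold higher number from compound 1 to compound 4 (0.26 log units; within the scatter) and so leaves the number inside the usual scatter. At this position, then, methoxycarbonyl and carboxy cannot be told apart on the core of compound 1. Nothing available explains this result.

As far as these compounds go, whether a primary amide or a nitrile in this place would read any differently remains open. So does whether the same swap would behave alike with the fluorine-bearing ring and the 4-carboxyphenyl group of compound 2.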